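The source may report more compounds than this note shows. Statements on the series, on what has been measured and on what is new or still open speak of the compounds shown alone.

Measured so far in an assay on L cells for inhibition of Protein-serine O-palmitoleoyltransferase porcupine (Mus musculus), read by reporter gene assay, with a stated time of 24 h; on this read-out higher numbers stand for an effect only at larger amounts of compound and lower numbers for an effect already at smaller amounts:
compound 1 `O=C(CSc1nc2c(c(=O)n1-c1ccccc1)SCC2)Nc1ccc(-c2ccncc2)cc1` gives 3 nM
compound 2 `O=C(CSc1nc2c(c(=O)n1-c1ccccc1)SCC2)Nc1nc(-c2ccccc2)cs1` gives 350 nM
compound 3 `COc1ccc2nc(NC(=O)CSc3nc4c(c(=O)n3-c3ccccc3)SCC4)ccc2c1` gives 580 nM

Compound 1 stands lowest of the three, and both other values lie well beyond the scatter of repeated measurements, so it is the most potent here. Compound 4 `O=C(CSc1nc2c(c(=O)n1-c1ccccc1)SCC2)Nc1ccc(N2CCCCC2)cc1` differs from compound 1 in one place: piperidin-1-yl in place of pyridin-4-yl on an aromatic carbon. Going by the values given here, no step between two measured compounds describes this change, so the expectation rests only on the spread seen across compounds 1 to 3. Because compound 1 gives 3 nM while the two other amides fall far higher, a weakening step beyond the scatter is expected in this assay; the estimated step from compound 1 to compound 4 is a 33-fold higher number from compound 1 to compound 4 (1.52 log units; beyond the scatter). Compound 4 is expected to give about 100 nM, within 15 nM to 800 nM.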

Compound 4, half-maximal effective concentration: 30 nM
Compound 4: the middle estimate sits 3.3-fold (0.52 log units) above what was measured, within the range that was stated.
By their numbers in this assay, from the lowest: compound 1; then compound 4; then compounds 2 and 3 (each within the scatter of the next).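

Putting piperidin-1-yl in place of pyridin-4-yl gives a 10-fold higher number from compound 1 to compound 4 (1.00 log units; beyond the scatter) in this assay, even though both groups are six-membered rings with the same counts of heavy atoms and hydrogen-bond acceptors. The aromatic ring is therefore not strictly required at this position, as compound 4 still gives 30 nM with a non-aromatic ring there, although the change does cost potency. Nothing measured here explains that loss.

The compounds shown leave open how a plain phenyl, a morpholin-4-yl or an open-chain dimethylamino group would fare at this position.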